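A few compounds are considered here, and "the series" means these few. Any claim that something is new, unique, unknown or untested is made for them only; others in the source may bear on it.

Measured in a functional assay on DU-145 cells (Homo sapiens) for inhibition, read by trypan blue exclusion, with a stated time of 96 h; on this read-out lower numbers stand for stronger inhibition of growth and higher numbers for weaker inhibition of growth:

compound 1, `Cc1ccc(C)c(/C=C(/Sc2ccc(Br)cc2)C(=O)c2ccc(Cl)cc2)c1`: 10000 nM
compound 2, `Cc1ccc(CS/C(=C/c2cc(C)ccc2C)C(=O)c2ccc(Cl)cc2)cc1`: 10000 nM
compound 3, `COc1ccccc1/C=C(\C(=O)c1ccc(Cl)cc1)S(=O)(=O)c1ccc(Br)cc1`: 10000 nM

Compound 1 and compound 2 share a core and differ in a single place: 4-methylbenzyl in place of 4-bromophenyl on a sulfur. That change made the step of no change at the digits printed from compound 1 to compound 2 (within the scatter), so the two sit together within the scatter of this assay. Compound 3 carries a different core; how its core differs from that of compound 1 is not broken down here. In this assay compound 3 gives 10000 nM, which is within the scatter of both compound 1 and compound 2, so no order among the three can be drawn.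

Compound 4, `COc1ccccc1/C=C(\C(=O)c1ccc(Cl)cc1)S(=O)(=O)Cc1ccc(C)cc1`, has not yet been measured in this assay. It differs from compound 3 by 4-methylbenzyl in place of 4-bromophenyl on a sulfonyl sulfur. Within the data shown here, this is the same kind of change as the one from compound 1 to compound 2, though the place is not identical: in compound 1 the group sits on a sulfur whose other neighbour is a double-bonded chain carbon, whereas in compound 3 it sits on a sulfonyl sulfur whose other neighbour is a double-bonded chain carbon. Because no change at the digits printed from compound 1 to compound 2 (within the scatter) shows no movement beyond the scatter, the same kind of change on compound 3 is expected to leave the read-out where it stands. Compound 4 is therefore expected to make the step of no change at the digits printed from compound 3 to compound 4 (within the scatter), arriving at an estimated 10000 nM, with a likely range from 5000 nM to 20000 nM.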

Compound 4, concentration for 50% growth inhibition: 10000 nM
Beside the measured number, compound 4's estimate shows no gap at the digits printed; the range from low to high includes it.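

In this assay, putting 4-methylbenzyl in place of 4-bromophenyl on a sulfonyl sulfur gave no change at the digits printed from compound 3 to compound 4 (within the scatter), and this step reads alike with the one made on a sulfur in the other core: the same change on two cores in this assay, no change at the digits printed (within the scatter) from compound 1 to compound 2 and no change at the digits printed (within the scatter) from compound 3 to compound 4, 1.0-fold (0.00 log units) apart, within the scatter of two such steps.
Across these two cores, then, the change carries over in the plain sense that both steps stay within the scatter and agree with each other. Among these compounds, this does not show that the two groups are interchangeable throughout the series: only two cores are involved, and all four compounds print the same value, so these steps cannot tell how the change would behave on a core that reads lower in growth inhibition.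

The compounds shown leave open whether anything other than 4-bromophenyl or 4-methylbenzyl on the sulfur, such as a chain ending in an amine, a carboxylic acid or a longer alkyl chain, would move the read-out at all. Among the compounds shown here, they also leave open whether any of these cores can reach stronger inhibition of growth, since no compound here stands apart from the others.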